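The source may report more compounds than this note shows. Statements on the series, on what has been measured and on what is new or still open speak of the compounds shown alone.

Among the compounds with values here, in an ADME assay (liver) for pharmacokinetics, with Liver microsome (Rattus norvegicus) as the target, using microsomes (on this read-out higher numbers stand for a longer-lived compound and lower numbers for a shorter-lived compound), compound 2 `CCOc1cc(NC(=O)C2(NC(=O)c3ccc4c(C5CCCC5)c(-c5ncc(Cl)cn5)n(C)c4c3)CCC2)ccc1/C=C/C(=O)OCCOc1ccccc1` gives 16.5 h, the higher of the two numbers known. Compound 1 `CCOc1cc(NC(=O)C2(NC(=O)c3ccc4c(C5CCCC5)c(-c5ncc(Cl)cn5)n(C)c4c3)CCC2)ccc1/C=C/C(=O)OCC(Cl)(Cl)Cl` gives 0.233 h, and the step of a 71-fold higher number from compound 1 to compound 2 (1.85 log units; beyond the scatter) shows how much the group on the ester chain can matter. Compound 3 `CCOc1cc(NC(=O)C2(NC(=O)c3ccc4c(C5CCCC5)c(-c5ncc(Cl)cn5)n(C)c4c3)CCC2)ccc1/C=C/C(=O)OCC(N)=O` differs from compound 2 by carbamoyl in place of phenoxymethyl on a saturated chain carbon bound to an oxygen next to a carbonyl group. Within the data shown here, no measured step tests carbamoyl here, so the single known step is only an indirect guide, and it makes a large change in either direction plausible. Compound 3 is expected to fall between its neighbours, with an estimated step of a 4.1-fold lower number from compound 2 to compound 3 (0.62 log units; beyond the scatter), giving an estimate of 4 h with a range from 0.8 h to 20 h.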

Compound 3, half-life: 0.383 h
For compound 3 the middle estimate is 10-fold (1.02 log units) above the measured one, outside the stated range (below it).
By their numbers in this assay, from the lowest: compounds 1 and 3 (each within the scatter of the next); then compound 2.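

In this assay, carbamoyl in place of phenoxymethyl gives a 43-fold lower number from compound 2 to compound 3 (1.63 log units; beyond the scatter), so the large step at this position is not unique to trichloromethyl. Carbamoyl and trichloromethyl, which share few atoms, cannot be told apart here, with a 1.6-fold higher number from compound 1 to compound 3 (0.22 log units; within the scatter), and only phenoxymethyl stands apart among the three groups. Nothing measured here explains this. On these data alone, it remains open whether the aromatic ring of phenoxymethyl or its chain of atoms matters more. A methoxymethyl group, which keeps the oxygen without the ring, or a benzyl group, which keeps the ring without the oxygen, would help separate the two.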